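The source may report more compounds than this note shows. Statements on the series, on what has been measured and on what is new or still open speak of the compounds shown alone.

Measured so far:
compound 1, `COc1cccc(-c2c(C)n(Cc3c(F)cccc3F)c(=O)n(C[C@H](C)NCc3ccccc3)c2=O)c1F` — 38 nM
compound 2, `COc1cccc(-c2c(C)n(Cc3c(F)cccc3F)c(=O)n(C[C@@H](C)NCc3nccs3)c2=O)c1F` — 6.1 nM

Among the compounds with values here, compound 2 holds the lowest of the two numbers in a functional assay on RBL cells for inhibition of Gonadotropin-releasing hormone receptor (Homo sapiens); on this read-out lower numbers stand for stronger inhibition and higher numbers for weaker inhibition; its only neighbour is compound 1, and the step of a 6.2-fold lower number from compound 1 to compound 2 (0.79 log units; beyond the scatter) lies beyond the scatter. Compound 3, `COc1cccc(-c2c(C)n(Cc3c(F)cccc3F)c(=O)n(C[C@H](C)NCc3sccc3C)c2=O)c1F`, differs from compound 2 by 1-(((3-methylthiophen-2-yl)methyl)amino)ethyl in place of 1-(((1,3-thiazol-2-yl)methyl)amino)ethyl on a saturated chain carbon bound to an aromatic nitrogen. Within the data shown here, no measured step covers this exact exchange; the one step that bears on the same position, a 6.2-fold lower number from compound 1 to compound 2 (0.79 log units; beyond the scatter), shows that the group on this chain carbon moves the number by a modest amount. A shift of similar size or smaller, direction uncertain but leaning towards a higher number, is what this reading suggests. The step that is expected is a 2.0-fold higher number from compound 2 to compound 3 (0.29 log units; within the scatter). Compound 3 is therefore estimated at 12 nM, with a range of 4 nM to 35 nM.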

Compound 3, half-maximal inhibitory concentration: 4 nM
For compound 3 the middle estimate is 3.0-fold (0.48 log units) above the measured one; low and high end bracket the measured number.
By their numbers in this assay, from the lowest: compounds 3 and 2 (each within the scatter of the next); then compound 1.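

In this assay, replacing 1-(((1,3-thiazol-2-yl)methyl)amino)ethyl with 1-(((3-methylthiophen-2-yl)methyl)amino)ethyl gives a 1.5-fold lower number from compound 2 to compound 3 (0.18 log units; within the scatter), so at this position a five-membered aromatic ring with 1 hetero atom and a methyl group performs on a par with the ring with 2 hetero atoms. Both five-membered rings now stand clear of phenyl, with a 9.5-fold lower number from compound 1 to compound 3 (0.98 log units; beyond the scatter), and no compound shown goes against this. Nothing available explains these steps. The exchange changes the ring and adds the methyl at once, so their separate contributions remain unresolved. An unsubstituted thiophen-2-yl or a furan-2-yl would separate them.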